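This account rests on a few compounds, and the source may have more. Where it says the series, first, only, none or still open, it means among the compounds named here.

In a physicochemical assay for inhibition, read by spectrophotometry, tested at 100 uM (on this read-out higher numbers stand for more inhibition at the one concentration tested (going by the name of the read-out) and lower numbers for less inhibition), compound 2 `COc1cc(NC(C)CCCNC(=O)NN)c2ncccc2c1` gives 70%, the second highest of the three numbers measured. Compound 1 `COc1cc(NC(C)CCCNC(=O)NNC(=O)NCCCCCO)c2ncccc2c1` gives 54%, while compound 3 `COc1cc(NC(C)CCCNC(=O)NNC(=O)NCCNC(c2ccccc2)(c2ccccc2)c2ccccc2)c2ncccc2c1` gives 88%. Compound 4 `COc1cc(NC(C)CCCNC(=O)NNC(=O)NC(CO)(CO)CO)c2ncccc2c1` is not yet measured; it differs from compound 2 by (2-hydroxy-1,1-bis(hydroxymethyl)ethyl)carbamoyl in place of hydrogen on an amine nitrogen. Going by the values given here, the one measured step that bears on this change is the removal of a (5-hydroxypentyl)carbamoyl group from the same amine nitrogen, a number 16 percentage points higher from compound 1 to compound 2 (beyond the scatter), so adding a hydroxyl-bearing carbamoyl group at this place went with less inhibition. Compound 3, which also carries a carbamoyl group there, shows the highest number, so the direction is not settled. For compound 4 a modest drop is expected, a number 15 percentage points lower from compound 2 to compound 4 (beyond the scatter), giving an estimated 55% with a range from 40% to 70%.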

Compound 4, a percentage reported as inhibition, at one concentration (the size of the read-out at that concentration, not a potency): 49%
Beside the measured number, compound 4's estimate is 6 percentage points above it, within the range that was stated.
By their numbers in this assay, from the lowest: compounds 4 and 1 (each within the scatter of the next); then compound 2; then compound 3.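

A second hydroxyl-bearing carbamoyl group on the amine nitrogen also goes with less inhibition (a number 21 percentage points lower from compound 2 to compound 4 (beyond the scatter)). Replacing 5-hydroxypentyl with the 2-hydroxy-1,1-bis(hydroxymethyl)ethyl group on the amide-type nitrogen makes no clear difference (a number 5 percentage points lower from compound 1 to compound 4 (within the scatter)), although compound 3, which also carries a carbamoyl group there, gives (88%). No measurement shown explains these differences. From the compounds shown here alone, it remains open whether the hydroxyl groups matter, as a plain pentyl chain would test, and how a carboxylic acid at the chain end would read.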